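Replacing 3-bromophenyl with thiophen-3-yl on a shared core

The source may hold more compounds than are shown below. What is called first, only, known or untested is meant among the compounds shown, and "the series" means these compounds.

Compound 1 `OC(c1ccc(Cl)cc1)(c1cccnc1)c1ccccc1Cl`: 61300 nM
Compound 2 `OC(c1ccc(Cl)cc1)(c1cccnc1)c1cccc(Br)c1`: 54100 nM

Both numbers come from an ADME assay on L6 cells (Rattus norvegicus) for cytotoxicity, read by resazurin assay, with a stated time of 72 h; on this read-out higher numbers stand for weaker inhibition and lower numbers for stronger inhibition. The two compounds stand level, and compound 2 has no clear separation from compound 1. Among the measured compounds shown here, the only measured step, a 1.1-fold lower number from compound 1 to compound 2 (0.05 log units; within the scatter), places 3-bromophenyl where 2-chlorophenyl stood.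

Compound 3 `OC(c1ccc(Cl)cc1)(c1cccnc1)c1ccsc1` changes that same place again. The difference is thiophen-3-yl in place of 3-bromophenyl on a saturated chain carbon bound to two aromatic carbons and an oxygen on a saturated carbon. For the measured compounds named here, no compound carrying thiophen-3-yl has been measured, so the evidence is thin and rests on one step at this place. That step, involving compound 2, stayed within the scatter, and it gives no direction for the new change. No shift beyond the scatter is therefore expected in this assay. The expected step is a 1.1-fold higher number from compound 2 to compound 3 (0.03 log units; within the scatter). For compound 3 the estimated value is 58000 nM. The estimated range for compound 3 runs from 29000 nM to 115000 nM.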

Compound 3, half-maximal inhibitory concentration: > 100000 nM
Compound 3: a limit, no number; the forecaster's own chance of this, stated with the estimate: 10%; at least 1.7-fold (0.23 log units) between middle value and limit.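

For compound 3 the read-out in this assay ends in a limit and not a number: the limit of > 100000 nM in this assay, at which 1 of the 3 values shown sits. At this place on the saturated chain carbon, thiophen-3-yl gives an at least 1.8-fold higher number from compound 2 to compound 3 (0.26 log units; that floor lies within the scatter), and set against the other phenyl compound it gives an at least 1.6-fold higher number from compound 1 to compound 3 (0.21 log units; that floor lies within the scatter). The two phenyl groups had stood level, whereas this first change to a five-membered aromatic ring with a hetero atom points towards a higher number, though both floors lie within the scatter, so the position is not yet shown to respond to the change.

The compounds shown leave open how far the true value of compound 3 lies past the limit, and so whether its step clears the scatter at all. They also leave open which part of the change matters, since thiophen-3-yl differs from 3-bromophenyl in ring size, in the sulfur atom and in the loss of the bromine, and an unsubstituted phenyl or a furan-3-yl at the same place would be needed to pull these apart.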